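Methyl on the core of compound 3: expected effect

The source may report more compounds than this note shows. Statements on the series, on what has been measured and on what is new or still open speak of the compounds shown alone.

Series notes. Of the compounds shown here, three have been measured in an assay on a protein complex for inhibition of ubiquitin carboxyl-terminal hydrolase 1/WD repeat-containing protein 48 (Homo sapiens), read by fluorescence; a lower number here means a stronger inhibitor, a higher number a weaker inhibitor: compound 1 `FC(F)(F)c1ccccc1-c1nc(NCc2ccc(C3CCCCC3)cc2)c2ccccc2n1`, compound 2 `CCc1ccccc1-c1nc(NCc2ccc(-c3cccnc3)cc2)c2ccccc2n1` and compound 3 `CC(C)c1ccccc1-c1nccc(NCc2ccc(-c3cccnc3)cc2)n1`. Compound 1 gives 9800 nM, compound 2 gives 780 nM, and compound 3 gives 150 nM, the lowest of the three numbers. Compound 3 stands clearly apart: compound 2 is its nearest neighbour, with a number higher by a margin beyond the scatter, and compound 1 is furthest, also beyond the scatter. No two of the measured compounds differ from each other in only one place, so none of these pairs can be read as a single structural step, and the cores of compound 1 and compound 2 differ from the core of compound 3.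

Compound 4 `Cc1cnc(-c2ccccc2C(C)C)nc1NCc1ccc(-c2cccnc2)cc1` differs from compound 3 by methyl in place of hydrogen on an aromatic carbon. Among the measured compounds shown here, no measured pair shows a change of this kind, so there is no precedent here for its size or direction. The expectation is a step that stays within the usual scatter, with no clear gain or loss. Compound 4 is therefore expected to give 150 nM, within a range from 50 nM to 450 nM. The estimated step of no change at the digits printed from compound 3 to compound 4 (within the scatter) in this assay is expected to be small, in either direction.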

Compound 4, half-maximal inhibitory concentration: 70 nM
The estimate for compound 4 lay 2.1-fold (0.33 log units) above the measured number, and the stated range covers the measured number.
By their numbers in this assay, from the lowest: compound 4; then compound 3; then compound 2; then compound 1.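

In this assay, among the compounds shown here, this is the first step that can be read as a single change: methyl in place of hydrogen on an aromatic carbon gives a 2.1-fold lower number from compound 3 to compound 4 (0.33 log units; beyond the scatter), a modest gain that nonetheless lies beyond the scatter. The earlier compounds shown here differed in more than one place and so could say nothing about this carbon, which sits on the six-membered aromatic ring with 2 nitrogen, ortho to a large group and para to a 2-isopropylphenyl group. The position therefore accepts a methyl with a lower number rather than a loss, though this rests on one pair of compounds, and no measurement given here bears on the reason for the step.

Going by these compounds, it remains open whether a longer chain such as ethyl, or a methoxy group, an amine or a chlorine atom on this carbon would extend, merely keep or reverse the step. Also open, on these data alone, is whether the methyl would give a similar step with a group other than the 2-isopropylphenyl group at the para position.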